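A few compounds are considered here, and "the series" means these few. Any claim that something is new, unique, unknown or untested is made for them only; others in the source may bear on it.

- Compound 1 `CC(C)(C)NCCCOc1ccc(S(=O)(=O)c2c(C3CC3)cn3ccccc23)cc1`: 66.5 nM
- Compound 2 `CCCCN(CCCC)CCCOc1ccc(S(=O)(=O)c2c(C3CCCCC3)cn3ccccc23)cc1`: 4070 nM

In a functional assay (aorta) with Rattus norvegicus as the target (a lower number here means a stronger inhibitor, a higher number a weaker inhibitor), compound 2 stands at 4070 nM, the higher of the two numbers and beyond the scatter from the other compound. Compound 3 `CCCCN(CCCC)CCCOc1ccc(S(=O)(=O)c2c(CC)cn3ccccc23)cc1` has ethyl in place of cyclohexyl on an aromatic carbon of compound 2 (ethyl in place of cyclohexyl on an aromatic carbon). Going by the values given here, no measured pair isolates this change. Compound 1, at 66.5 nM, differs from compound 2 at this carbon and elsewhere, so it offers only a weak hint that the number will fall. The expected change, a 5.8-fold lower number from compound 2 to compound 3 (0.76 log units; beyond the scatter), is a moderate drop beyond the scatter. Compound 3 is estimated at 700 nM, with an expected range of 150 nM to 3500 nM.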

Compound 3, half-maximal inhibitory concentration: 31.3 nM
Beside the measured number, compound 3's estimate is 22-fold (1.35 log units) above it; measured number below the stated range.
By their numbers in this assay, from the lowest: compound 3; then compound 1; then compound 2.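

Replacing cyclohexyl with ethyl on this aromatic carbon gives a 130-fold lower number from compound 2 to compound 3 (2.11 log units; beyond the scatter) in this assay while the rest of the molecule stays the same. This pair shows that the group at this one carbon can, on its own, produce a large change, which compound 1 could not show because it also differs elsewhere. No evidence on the cause of this step is at hand.

From the compounds shown here alone, with only ethyl and cyclohexyl compared here, the trend between them remains open. A methyl, isopropyl or phenyl group at this carbon would help define it.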